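A few compounds are considered here, and "the series" means these few. Any claim that something is new, unique, unknown or untested is made for them only; others in the source may bear on it.

Series values in a functional assay on A549 cells (Homo sapiens) for inhibition, read by MTT assay, with a stated time of 48 h; a higher number here means a weaker inhibitor, a lower number a stronger inhibitor:

- compound 1 `Oc1cccc(C(c2c[nH]c3ccc(Br)cc23)c2c[nH]c3ccc(Br)cc23)c1` gives 8000 nM
- compound 2 `CCCCCCCC(c1c[nH]c2ccc(Br)cc12)c1c[nH]c2ccc(Br)cc12` gives 3500 nM
- compound 3 `N#Cc1ccc2[nH]cc(C(c3ccc(Cl)cc3)c3c[nH]c4ccc(C#N)cc34)c2c1` gives > 100000 nM (a limit of the assay, not a number)

Compound 3 sits at the limit of > 100000 nM in this assay, at which 1 of the 3 values shown sits, so it offers a limit and no number to step from. Compound 4 `N#Cc1ccc2[nH]cc(C(c3ccc(Br)cc3)c3c[nH]c4ccc(C#N)cc34)c2c1` is the next compound to be read in this assay. Its difference from compound 3 is bromo in place of chloro on an aromatic carbon, which is bromo in place of chloro on an aromatic carbon, or 4-chlorophenyl to 4-bromophenyl when cut one bond further out.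

Going by the values given here, no measured step exchanges one halogen for another. Among the compounds with values here, the only measured step, a 2.3-fold lower number from compound 1 to compound 2 (0.36 log units; beyond the scatter), is modest and involves heptyl in place of 3-hydroxyphenyl, so it bears on this change only loosely and gives no direction. Within the data shown here, with so small an exchange and no closer precedent, no step beyond the scatter is expected, and compound 4 may well also be reported only as a limit. The expected change is a number no higher from compound 3 to compound 4 (the limit leaves the size open), an estimate that treats the limit as its starting point. The estimated value for compound 4 is 100000 nM, with an expected range of 30000 nM to 200000 nM.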

Compound 4, half-maximal inhibitory concentration: > 100000 nM
Compound 4 gave a limit, no number (the forecaster's own chance of this, stated with the estimate: 70%); the middle value sits exactly at the limit.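

In this assay, compound 3 and compound 4 both stop at a limit, not a number, so no step can be read between them: the limit of > 100000 nM in this assay, at which 2 of the 4 values shown sit.

The compounds shown leave open whether bromo in place of chloro on this aromatic carbon changes the read-out at all, since neither compound gives a number.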